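This account rests on a few compounds, and the source may have more. Where it says the series, first, only, none or still open, it means among the compounds named here.

The measured compounds, all tested in a functional assay on U-87MG ATCC cells (Homo sapiens) for cytotoxicity, read by MTT assay, with a stated time of 72 h; on this read-out higher numbers stand for weaker inhibition and lower numbers for stronger inhibition:

compound 1, `COc1cc2c(Oc3ccc(NC(=O)c4nnn(-c5ccccc5)c4C)cc3F)ccnc2cc1OCCCN1CCCCC1`: 1130 nM
compound 2, `COc1cc2c(Oc3ccc(NC(=O)c4nnn(-c5ccc(F)cc5)c4C(F)(F)F)cc3F)ccnc2cc1OCCCN1CCCCC1`: 1100 nM
compound 3, `COc1cc2c(Oc3ccc(NC(=O)c4nnn(-c5ccccc5)c4C)cc3F)ccnc2cc1OCCCN1CCC(C)CC1`: 1240 nM

Compound 1 and compound 3 share one core and differ in a single spot: methyl in place of hydrogen on a saturated ring carbon. In this assay that change gave a 1.1-fold higher number from compound 1 to compound 3 (0.04 log units; within the scatter), so the two compounds cannot be told apart by this read-out. Compound 2 carries a different core; the difference between the two cores is not broken down here, and the values of compound 1 and compound 2 in this assay lie close together.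

Compound 4, `COc1cc2c(Oc3ccc(NC(=O)c4nnn(-c5ccc(F)cc5)c4C(F)(F)F)cc3F)ccnc2cc1OCCCN1CCC(C)CC1`, has not yet been measured. It stands to compound 2 as compound 3 stands to compound 1: methyl in place of hydrogen on a saturated ring carbon. The place of the change is described in the same words for both pairs, so this is the same change made on the other core.

Because the same change gave a 1.1-fold higher number from compound 1 to compound 3 (0.04 log units; within the scatter), the step from compound 2 to compound 4 in this assay is expected to be equally small, about a 1.1-fold higher number from compound 2 to compound 4 (0.04 log units; within the scatter). For the measured compounds named here, there is no measured case in which this change moved the number by much, but there is also only one example, so the expectation carries some uncertainty. Compound 4 is therefore estimated at 1200 nM in this assay, with a likely range from 600 nM to 2400 nM.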

Compound 4, half-maximal inhibitory concentration: 800 nM
Compound 4: middle estimate off by 1.5-fold (0.18 log units), on the high side, and the stated range covers the measured number.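

The added methyl, which turns piperidin-1-yl into 4-methylpiperidin-1-yl, gives a 1.4-fold lower number from compound 2 to compound 4 (0.14 log units; within the scatter) in this assay. Set beside the earlier example, this step does not differ from it beyond what repeat measurements would produce: the same change on two cores in this assay, a 1.1-fold higher number (0.04 log units; within the scatter) from compound 1 to compound 3 and a 1.4-fold lower number (0.14 log units; within the scatter) from compound 2 to compound 4, 1.5-fold (0.18 log units) apart, within the scatter of two such steps. On these two cores, then, the change carries over in the sense that the read-out stays within the scatter both times, but two pairs show only that, and the opposite directions of the printed steps are too small to mean that the methyl acts differently on each core, or that it would behave the same way on a third core.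

The compounds shown leave open whether this ring tolerates anything beyond a single methyl in this assay, for example an ethyl or a phenyl group on the same ring carbon, or a hydroxyl group there. Also open, as far as these compounds go, is what happens when the ring itself is replaced, for instance by a morpholine ring or a dimethylamino group in place of piperidin-1-yl, since every compound here keeps the same piperidine ring.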